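Trifluoromethyl in Place of Nitro on Compound 3

This account rests on a few compounds, and the source may have more. Where it says the series, first, only, none or still open, it means among the compounds named here.

The three measured compounds share one core and differ only in the group on the six-membered aromatic ring of carbon only. Compound 1 `COc1ccc(-c2noc(CN3N=N[C@@H]4C(=O)N(c5ccccc5)C(=O)[C@@H]43)n2)cc1` carries methoxy there, compound 2 `O=C1[C@H]2N=NN(Cc3nc(-c4ccccc4)no3)[C@H]2C(=O)N1c1ccccc1` carries hydrogen, and compound 3 `O=C1[C@H]2N=NN(Cc3nc(-c4ccc([N+](=O)[O-])cc4)no3)[C@H]2C(=O)N1c1ccccc1` carries nitro. In an ADME assay on L6 cells (Rattus norvegicus) for cytotoxicity, read by resazurin assay, with a stated time of 72 h (on this read-out lower numbers stand for stronger inhibition and higher numbers for weaker inhibition), compound 2 gives 47.3 ug/mL. Compound 1 gives only a limit of the assay, > 100 ug/mL. Compound 3 likewise gives only a limit, > 100 ug/mL, so its exact place on the scale is not fixed; it sits at the limit of > 100 ug/mL in this assay, at which 2 of the 3 values shown sit. The measured steps read an at least 2.1-fold lower number from compound 1 to compound 2 (0.32 log units; beyond the scatter) and an at least 2.1-fold higher number from compound 2 to compound 3 (0.32 log units; beyond the scatter), while a step that the two limits leave unreadable from compound 1 to compound 3.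

Compound 4 `O=C1[C@H]2N=NN(Cc3nc(-c4ccc(C(F)(F)F)cc4)no3)[C@H]2C(=O)N1c1ccccc1` has not yet been measured. It differs from compound 3 in that (trifluoromethyl in place of nitro on an aromatic carbon). The two readable steps show that the ring bearing hydrogen gives the lowest number, while both substituted rings reach the limit. Trifluoromethyl is a third substituent on that aromatic carbon, no measured step involves it, and the limit on compound 3 leaves the starting point open. The step from compound 3 to compound 4 is therefore expected to be small or not readable, an at least 1.1-fold lower number from compound 3 to compound 4 (0.04 log units; that floor lies within the scatter). Compound 4 is accordingly estimated at 90 ug/mL, within a range from 40 ug/mL to 200 ug/mL, with a real chance that the assay again reports only a limit.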

Compound 4, half-maximal inhibitory concentration: 44.4 ug/mL
The estimate for compound 4 lay 2.0-fold (0.31 log units) above the measured number; low and high end bracket the measured number.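

In this assay, going by these compounds alone, a substituent on this aromatic carbon does not by itself push the number to the limit: trifluoromethyl in place of nitro gives an at least 2.2-fold lower number from compound 3 to compound 4 (0.35 log units; beyond the scatter), which puts a substituted ring on the readable part of the scale for the first time. Trifluoromethyl in place of hydrogen gives a 1.1-fold lower number from compound 2 to compound 4 (0.03 log units; within the scatter), so compound 2 and compound 4 cannot be told apart here, and the earlier contrast between the unsubstituted ring and the substituted rings does not hold for every substituent. Trifluoromethyl in place of methoxy gives an at least 2.2-fold lower number from compound 1 to compound 4 (0.35 log units; beyond the scatter), so the four compounds fall into two pairs, with compound 2 and compound 4 on the measured scale, while compound 1 and compound 3 stay unresolved: the limit of > 100 ug/mL in this assay, at which 2 of the 4 values shown sit.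

The compounds shown leave open whether this division into two pairs would hold for other groups on this aromatic carbon, such as a chlorine atom, an amine or a carboxylic acid. They also leave open how far compound 1 and compound 3 actually lie from each other, and how far either lies from compound 4.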